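Swapping Methoxy for Methylsulfonyl on a Bcl-2 Sulfonamide

This account rests on a few compounds, and the source may have more. Where it says the series, first, only, none or still open, it means among the compounds named here.

Compound 1 `CN(C)CC[C@H](CSc1ccccc1)Nc1ccc(S(=O)(=O)NC(=O)c2ccc(N3CCN(Cc4ccccc4)CC3)cc2)cc1[N+](=O)[O-]`: 39.8 nM
Compound 2 `COc1ccc(-c2ccccc2CN2CCN(c3ccc(C(=O)NS(=O)(=O)c4ccc(N[C@H](CCN(C)C)CSc5ccccc5)c([N+](=O)[O-])c4)cc3)CC2)cc1`: < 1 nM

In an assay on isolated protein for displacement of a labelled ligand from Apoptosis regulator Bcl-2 (Homo sapiens), read by fluorescence polarization (a lower number here means a stronger inhibitor, a higher number a weaker inhibitor), compound 1 gives 39.8 nM. Compound 2 reaches only a limit of this assay, < 1 nM, which is the limit of < 1 nM in this assay, at which 1 of the 2 values shown sits. Compound 3 `CN(C)CC[C@H](CSc1ccccc1)Nc1ccc(S(=O)(=O)NC(=O)c2ccc(N3CCN(Cc4ccccc4-c4ccc(S(C)(=O)=O)cc4)CC3)cc2)cc1[N+](=O)[O-]` differs from compound 2 by methylsulfonyl in place of methoxy on an aromatic carbon. For the measured compounds named here, the single measured step, an at least 39-fold lower number from compound 1 to compound 2 (1.59 log units; beyond the scatter), concerns a different change and does not test methoxy against methylsulfonyl. Without a direct comparison, the step of an at least 1.5-fold higher number from compound 2 to compound 3 (0.17 log units; that floor lies within the scatter) is expected to be small. Compound 3 is therefore expected to give 1.5 nM, within a range from 0.3 nM to 8 nM.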

Compound 3, inhibition constant: < 1 nM
Compound 3: only a limit was reported (the forecaster's own chance of this, stated with the estimate: 35%); middle value at least 1.5-fold (0.17 log units) away from the limit.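

Compound 3 gives < 1 nM in this assay, which is a limit of the assay and not a number. Placing 4-(methylsulfonyl)phenyl on the aromatic carbon that carries hydrogen in compound 1 gives an at least 39-fold lower number from compound 1 to compound 3 (1.59 log units; beyond the scatter), so the large gain at this position is not confined to 4-methoxyphenyl. Methoxy and methylsulfonyl cannot be ranked, and the step between them cannot be read, because both values are limits: the limit of < 1 nM in this assay, at which 2 of the 3 values shown sit.

Going by these compounds, whether a carboxylic acid or an amine in the same place would also reach this limit remains open. On these data alone, how far compound 2 and compound 3 truly lie apart also remains open.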